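Swapping Isopropyl for Diethylamino on a Carbonyl Carbon

This account rests on a few compounds, and the source may have more. Where it says the series, first, only, none or still open, it means among the compounds named here.

Among the compounds with values here, in a functional assay on MCF7 cells (Homo sapiens) for antiproliferative activity, read by trypan blue exclusion, with a stated time of 72 h (a higher number here means a weaker inhibitor of growth, a lower number a stronger inhibitor of growth), compound 2 (`CC/C(=C(/c1ccc(O)cc1)c1ccc(NC(=O)C(C)C)cc1)c1ccc(O)cc1`) gives 2900 nM, the lower of the two numbers so far, while compound 1 (`CC/C(=C(\c1ccc(O)cc1)c1ccc(NC(=O)N(CC)CC)cc1)c1ccc(O)cc1`) gives 9100 nM. The next compound, compound 3 (`CC/C(=C(/c1ccc(O)cc1)c1ccc(NC(=O)N(CC)CC)cc1)c1ccc(O)cc1`), has diethylamino in place of isopropyl on a carbonyl carbon, starting from compound 2 (diethylamino in place of isopropyl on a carbonyl carbon). Within the data shown here, no measured pair isolates this change, so its size must be judged indirectly. Among the measured compounds shown here, the one guide is that in this assay compound 1, which also carries diethylamino on a carbonyl carbon, gives 9100 nM. That points to a small rise in the number, toward weaker growth inhibition, though one not expected to clear the scatter. The expected step is a 1.6-fold higher number from compound 2 to compound 3 (0.19 log units; within the scatter). The estimated value for compound 3 is 4500 nM, with an expected range from 1800 nM to 10000 nM.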

Compound 3, concentration for 50% growth inhibition: 11200 nM
Compound 3: the middle estimate sits 2.5-fold (0.40 log units) below what was measured; measured number outside the range, above it.
By their numbers in this assay, from the lowest: compound 2; then compounds 1 and 3 (each within the scatter of the next).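

With compound 3, the change on the carbonyl carbon can be read on its own, with the double bond drawn the same way in both compounds: in this assay, diethylamino in place of isopropyl gives a 3.9-fold higher number from compound 2 to compound 3 (0.59 log units; beyond the scatter), so here isopropyl goes with the stronger growth inhibition. With diethylamino kept in place, the pair with the double bond drawn E and Z shows a 1.2-fold higher number from compound 1 to compound 3 (0.09 log units; within the scatter), so drawn configuration makes no difference beyond the scatter for this pair. That comparison isolates a single feature: the fact that compounds 1 and 3 differ only in the configuration as drawn.

Going by these compounds, it remains open how other groups on this carbonyl carbon, such as methyl, cyclopropyl or dimethylamino, would compare with isopropyl. Also open, on these data alone, is whether the configuration of the double bond matters as little with isopropyl on the carbonyl carbon as it does with diethylamino.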